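A few compounds are considered here, and "the series" means these few. Any claim that something is new, unique, unknown or untested is made for them only; others in the source may bear on it.

Measured in a functional assay on HeLa cells (Homo sapiens) for inhibition, read by MTT assay, with a stated time of 48 h; a lower number here means a stronger inhibitor, a higher number a weaker inhibitor:

- Compound 1 `COc1cccc(C(c2c[nH]c3ccc(Br)cc23)c2c[nH]c3ccc(Br)cc23)c1OC`: 64500 nM
- Compound 2 `COc1ccc(OC)c(C(c2c[nH]c3ccc(Br)cc23)c2c[nH]c3ccc(Br)cc23)c1`: 5100 nM

Of these two compounds, compound 2 has the lower number, 5100 nM, which makes it the stronger inhibitor of the pair. The next compound, compound 3 `CN(C)c1ccc(C(c2c[nH]c3ccc(Br)cc23)c2c[nH]c3ccc(Br)cc23)cc1`, differs from it in one place: 4-(dimethylamino)phenyl in place of 2,5-dimethoxyphenyl on a saturated chain carbon bound to two aromatic carbons. In words, 4-(dimethylamino)phenyl stands in place of 2,5-dimethoxyphenyl on a saturated chain carbon bound to two aromatic carbons.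

Among the measured compounds shown here, only one measured step bears on this change: a 13-fold lower number from compound 1 to compound 2 (1.10 log units; beyond the scatter). That step is large, and it came from exchanging one group at this same place, so a sizeable shift in this assay would not be surprising here. However, no measured compound carries 4-(dimethylamino)phenyl, so the data give no direct guide to the direction. For the measured compounds named here, with compound 2 at 5100 nM, the lower of only two numbers, a move to a higher number seems somewhat more likely than a further fall. The expected change is a 2.4-fold higher number from compound 2 to compound 3 (0.37 log units; beyond the scatter). The estimated value for compound 3 is 12000 nM, with an expected range of 3000 nM to 50000 nM.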

Compound 3, half-maximal inhibitory concentration: 12800 nM
The estimate for compound 3 lay 1.1-fold (0.03 log units) below the measured number; the measured number falls inside the stated range.
By their numbers in this assay, from the lowest: compound 2; then compound 3; then compound 1.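

In this assay, placing 4-(dimethylamino)phenyl on the saturated chain carbon bound to two aromatic carbons gives a 2.5-fold higher number from compound 2 to compound 3 (0.40 log units; beyond the scatter) when it replaces 2,5-dimethoxyphenyl, and a 5.0-fold lower number from compound 1 to compound 3 (0.70 log units; beyond the scatter) when it replaces 2,3-dimethoxyphenyl. This shows that a ring with neither methoxy group can still be tolerated at this place: compound 3 ranks behind compound 2 but ahead of compound 1, and both new steps are smaller than the gap of a 13-fold lower number from compound 1 to compound 2 (1.10 log units; beyond the scatter) that separates the two dimethoxyphenyl compounds. The data contain no measurement that accounts for this order.

The compounds shown leave open whether the shift from compound 2 to compound 3 follows from losing the two methoxy groups or from gaining the dimethylamino group, as both changes occur together in one swap. A plain phenyl, a 4-methoxyphenyl or a 4-aminophenyl at this same place would help to separate these two parts of the change.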